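A further methoxy group on compound 2

A few compounds are considered here, and "the series" means these few. Any claim that something is new, unique, unknown or untested is made for them only; others in the source may bear on it.

Measured in a functional assay on HeLa cells (Homo sapiens) for cytotoxicity, read by MTT assay, with a stated time of 24 h; a higher number here means a weaker inhibitor, a lower number a stronger inhibitor:
- Compound 1 `C/C(=N\NC(=O)/C(C#N)=C/c1ccc(O)cc1)c1c(O)c2ccc(O)cc2oc1=O`: 6020 nM
- Compound 2 `COc1ccc(/C=C(\C#N)C(=O)N/N=C(\C)c2c(O)c3ccc(O)cc3oc2=O)cc1OC`: 13500 nM

Of the two, compound 2 has the higher number at 13500 nM, which makes it the weaker inhibitor. Compound 3 `COc1cc(/C=C(\C#N)C(=O)N/N=C(\C)c2c(O)c3ccc(O)cc3oc2=O)cc(OC)c1OC` carries one change: methoxy in place of hydrogen on an aromatic carbon. Among the measured compounds shown here, the only measured step that bears on this is a 2.2-fold higher number from compound 1 to compound 2 (0.35 log units; beyond the scatter), a modest one, with 3,4-dimethoxyphenyl in place of 4-hydroxyphenyl. That was a different change, so it is only a loose guide. A small further rise is expected in this assay, and it may stay within the scatter. The expected step is a 1.1-fold higher number from compound 2 to compound 3 (0.05 log units; within the scatter). For compound 3 the estimate is 15000 nM, with an expected range from 6500 nM to 35000 nM.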

Compound 3, half-maximal inhibitory concentration: 18500 nM
The estimate for compound 3 lay 1.2-fold (0.09 log units) below the measured number, within the range that was stated.
By their numbers in this assay, from the lowest: compound 1; then compounds 2 and 3 (each within the scatter of the next).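

On the aromatic carbon ortho to a methoxy group, methoxy in place of hydrogen gives a 1.4-fold higher number from compound 2 to compound 3 (0.14 log units; within the scatter) in this assay. Compound 2 and compound 3 therefore cannot be told apart in this assay, so this position tolerates a further methoxy group without a readable change. No supporting measurement bears on the reason for this result. As far as these compounds go, whether an amine or a carboxylic acid on this same carbon would also leave the number within the scatter remains open. A single step also cannot show how a hydroxy group would behave here.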